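Halogen swap on the anilino ring of compound 1

The source may hold more compounds than are shown below. What is called first, only, known or untested is meant among the compounds shown, and "the series" means these compounds.

Measured so far:
- compound 1, `Cc1cnc(Nc2ccc(Cl)cc2)nc1Nc1nc2ccccc2s1`: > 50000 nM
- compound 2, `COc1ccc2nc(Nc3ccnc(Nc4ccc(S(C)(=O)=O)cc4)n3)sc2c1`: 32700 nM
- compound 3, `Cc1cnc(Nc2ccc(S(C)(=O)=O)cc2)nc1Nc1nc2ccc(Cl)cc2s1`: 5900 nM

In a functional assay on MDA-MB-231 cells (Homo sapiens) for antiproliferative activity, read by MTT assay, with a stated time of 48 h (on this read-out higher numbers stand for weaker inhibition and lower numbers for stronger inhibition), compound 1 gives only a limit, > 50000 nM, not a number. Within the same assay compound 2 gives 32700 nM and compound 3 gives 5900 nM; neither shares a single-point difference with compound 1, so no step is drawn to them. Compound 1 therefore stands at the weak end of the three, at the limit (the limit of > 50000 nM in this assay, at which 1 of the 3 values shown sits).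

Compound 4, `Cc1cnc(Nc2ccc(F)cc2)nc1Nc1nc2ccccc2s1`, differs from compound 1 by fluoro in place of chloro on an aromatic carbon. Among the measured compounds shown here, no measured step of this kind exists in the set. The expected step of a number no higher from compound 1 to compound 4 (the limit leaves the size open) is none beyond the scatter, so compound 4 is estimated at 50000 nM in this assay, with a range of 15000 nM to 150000 nM.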

Compound 4, half-maximal inhibitory concentration: > 50000 nM
Compound 4 gave a limit, no number; the forecaster's own chance of this, stated with the estimate: 60%; the middle value lies on the limit itself.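

Compound 1 and compound 4 each give only a limit, so no step can be read for fluoro in place of chloro: the limit of > 50000 nM in this assay, at which 2 of the 4 values shown sit.

The compounds shown leave open whether fluoro and chloro differ at all at this place.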